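The source may report more compounds than this note shows. Statements on the series, on what has been measured and on what is new or still open speak of the compounds shown alone.

Going by the values given here, in a functional assay on HT-1080 cells (Homo sapiens) for antiproliferative activity, read by MTT assay, with a stated time of 72 h (on this read-out lower numbers stand for stronger inhibition and higher numbers for weaker inhibition), three compounds have numbers so far. Compound 1 (`COc1ccc(-c2ssc(=O)c2-c2cc(OC)c(OC)c(OC)c2)cc1[N+](=O)[O-]`) gives 4220 nM and compound 2 (`COc1ccc(-c2ssc(=O)c2-c2cc(OC)c(OC)c(OC)c2)cc1N`) gives 147 nM in the same test. Putting amino in place of nitro on an aromatic carbon thus produces a 29-fold lower number from compound 1 to compound 2 (1.46 log units; beyond the scatter) in this pair. Compound 3 (`COc1ccc(-c2ss/c(=N/O)c2-c2cc(OC)c(OC)c(OC)c2)cc1`) carries an oxime where compound 1 and compound 2 carry a carbonyl, and compound 3 gives 6660 nM here. That value lies within the scatter of compound 1 and far higher than the value of compound 2.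

Compound 4 (`COc1ccc(-c2ss/c(=N/O)c2-c2cc(OC)c(OC)c(OC)c2)cc1N`) departs from compound 3 by one change (amino in place of hydrogen on an aromatic carbon), amino in place of hydrogen on an aromatic carbon, ortho to a methoxy group. Among the compounds with values here, no measured pair shows this exact replacement, and no measured pair carries the oxime on both sides. Within the data shown here, the only guide is therefore indirect, namely a 29-fold lower number from compound 1 to compound 2 (1.46 log units; beyond the scatter) with the same amino group entering at the same place. On that basis a large step toward a lower number is expected in this assay, though with wide uncertainty. For compound 4 the estimated value is 350 nM with an expected range from 60 nM to 2000 nM in this test. This estimate means an expected 19-fold lower number from compound 3 to compound 4 (1.28 log units; beyond the scatter) overall.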

Compound 4, half-maximal inhibitory concentration: 9360 nM
Compound 4: the middle estimate sits 27-fold (1.43 log units) below what was measured, outside the stated range (above it).
By their numbers in this assay, from the lowest: compound 2; then compounds 1, 3 and 4 (each within the scatter of the next, the first and the last beyond it).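

In this assay, placing amino ortho to a methoxy group on the oxime-bearing core gives a 1.4-fold higher number from compound 3 to compound 4 (0.15 log units; within the scatter), so on this core the change from 4-methoxyphenyl to 3-amino-4-methoxyphenyl makes no difference that can be told from the scatter. The earlier step, a 29-fold lower number from compound 1 to compound 2 (1.46 log units; beyond the scatter), therefore does not carry over as a general effect of amino at this place: with the same 3-amino-4-methoxyphenyl group, compound 2, which carries the carbonyl, gives 147 nM, and compound 4, which carries the oxime, gives 9360 nM. No measurement offered here explains why the amino group counts in one setting and not in the other.

Still open, going by these compounds, is what amino does against plain hydrogen when the carbonyl is present, and whether nitro at this place on the oxime-bearing core would read any differently from amino or hydrogen. Equally open is how a hydroxyl or an acetamide at this place would behave on either core, so the compounds shown cannot yet say whether any group here can lower the number when the oxime is present.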